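Reshaping the Seven-Carbon Chain on the Aromatic Nitrogen

The compounds below may be only part of what the source reports. "The series", "measured", "known", "first", "only" and "open" are said of these compounds alone.

Three compounds sharing one core carry different alkyl groups on the aromatic nitrogen. Compound 1 `CCCCCCCn1ccc2cc(/C(C)=C/C(=O)Nc3ccccc3OCCCC(=O)O)ccc21`, with a heptyl group, gives 120 nM in an assay on Prostate gland for inhibition of steroid 5-alpha-reductase (Rattus norvegicus); on this read-out higher numbers stand for weaker inhibition and lower numbers for stronger inhibition. Compound 2 `CCC(C)n1ccc2cc(/C(C)=C/C(=O)Nc3ccccc3OCCCC(=O)O)ccc21`, with a sec-butyl group, gives 67 nM in this assay. Compound 3 `CCCC(C(C)C)n1ccc2cc(/C(C)=C/C(=O)Nc3ccccc3OCCCC(=O)O)ccc21`, with a 1-isopropylbutyl group, gives 7.2 nM in this assay. Compound 3 stands lowest of the three numbers: its nearest number is reached by a 9.3-fold lower number from compound 2 to compound 3 (0.97 log units; beyond the scatter) and the furthest by a 17-fold lower number from compound 1 to compound 3 (1.22 log units; beyond the scatter), while a 1.8-fold lower number from compound 1 to compound 2 (0.25 log units; within the scatter) stays within the scatter.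

Compound 4 `CCCCC(CC)n1ccc2cc(/C(C)=C/C(=O)Nc3ccccc3OCCCC(=O)O)ccc21` differs from compound 3 by 1-ethylpentyl in place of 1-isopropylbutyl on an aromatic nitrogen. Both steps ending on the 1-isopropylbutyl group bear on this change: a 17-fold lower number from compound 1 to compound 3 (1.22 log units; beyond the scatter) was large and a 9.3-fold lower number from compound 2 to compound 3 (0.97 log units; beyond the scatter) was modest, and compound 4 keeps the same atoms in another branched chain rather than returning to a heptyl or sec-butyl group. A small step is therefore expected in this assay, leaning toward a slightly higher number, as a 1.7-fold higher number from compound 3 to compound 4 (0.22 log units; within the scatter). Compound 4 is estimated at 12 nM in this assay, with a range from 4 nM to 40 nM.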

Compound 4, half-maximal inhibitory concentration: 7.1 nM
Compound 4: the middle estimate sits 1.7-fold (0.23 log units) above what was measured, and the stated range covers the measured number.
By their numbers in this assay, from the lowest: compounds 4 and 3 (each within the scatter of the next); then compounds 2 and 1 (each within the scatter of the next).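

In this assay, moving from 1-isopropylbutyl to 1-ethylpentyl on the aromatic nitrogen gives a 1.0-fold lower number from compound 3 to compound 4 (0.01 log units; within the scatter), so two differently branched chains built from the same atoms cannot be told apart at this position. The advantage seen with the 1-isopropylbutyl group is therefore not confined to that one branching pattern: compound 4 also reaches a 17-fold lower number from compound 1 to compound 4 (1.23 log units; beyond the scatter), starting from the unbranched heptyl chain with the same atoms, and a 9.4-fold lower number from compound 2 to compound 4 (0.97 log units; beyond the scatter), starting from the shorter sec-butyl group. No supporting evidence is available to explain why these chains compare as they do.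

The four compounds leave open whether the same low numbers would persist with a longer branched chain, such as 1-propylpentyl, or with a ring-bearing group, such as cyclohexyl or benzyl, on the aromatic nitrogen. They also leave open how a branched chain carrying an ether oxygen or an amine would compare at this position, since every group shown here consists of carbon and hydrogen alone.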